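Compound 2 to compound 3: oxiranyl out, formyl in

A few compounds are considered here, and "the series" means these few. Any claim that something is new, unique, unknown or untested is made for them only; others in the source may bear on it.

In a functional assay on NALM-6 cells (Homo sapiens) for cytotoxicity, with a stated time of 72 h (on this read-out lower numbers stand for an effect already at smaller amounts and higher numbers for an effect only at larger amounts of compound), compound 1 `C=C[C@@](C)(/C=C/c1ccc(OC)cc1)CCC=C(C)C` gives > 43400 nM as its result, which is a limit of the assay and not a number. Compound 2 `C=C[C@@](C)(/C=C/c1ccc(O)cc1)CCC1OC1(C)C` also gives only a limit (> 43400 nM) and no number. The data so far therefore consist of the limit of > 43400 nM in this assay, at which 2 of the 2 values shown sit, and nothing more, so compound 2 cannot be ranked against compound 1.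

Compound 3 `C=C[C@@](C)(/C=C/c1ccc(O)cc1)CCC=O` has not yet been measured. It carries formyl in place of 3,3-dimethyloxiran-2-yl on a saturated chain carbon, three bonds along the chain from two double-bonded chain carbons. Among the measured compounds shown here, no measured pair of compounds differing in one place is available to show how large such a step might be.

The expected change a step that the limit leaves unreadable from compound 2 to compound 3 is none beyond the usual scatter, and the assay will most likely report only a limit again. This expectation rests on compound 2 and its limit (> 43400 nM) in this assay as the only nearby result. Compound 3 is estimated at 45000 nM (expected range 20000 nM to 90000 nM).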

Compound 3, half-maximal effective concentration: > 43400 nM
Compound 3 gave a limit, no number (the forecaster's own chance of this, stated with the estimate: 80%); the middle value is on the limit's open side.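

In this assay compound 3 gives > 43400 nM, which is a limit of the assay and not a number. Compound 2 also gives only a limit, and no step can be read between compound 2 and compound 3. Whether formyl in place of 3,3-dimethyloxiran-2-yl changes the effect at all, and whether any of these compounds would give a number in this assay, stays open.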